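Methylsulfonyl for chloro on the shared core

A few compounds are considered here, and "the series" means these few. Any claim that something is new, unique, unknown or untested is made for them only; others in the source may bear on it.

Compound 3 `Cc1cc(Cl)c(NC(=O)N(Cc2ccc(Oc3ccc(F)cc3)cc2)C2CCCCCC2)c(Cl)n1` gives 14 nM in an assay for inhibition of acyl-CoA:cholesterol acyltransferase (Oryctolagus cuniculus), using microsomes (on this read-out higher numbers stand for weaker inhibition and lower numbers for stronger inhibition), the lowest of the three numbers shown; compound 2 `COc1nc(C)cc(SC)c1NC(=O)N(Cc1ccc(Oc2ccc(F)cc2)cc1)C1CCCCCC1` gives 29 nM and compound 1 `COc1cc(C)nc(OC)c1NC(=O)N(Cc1ccc(Oc2ccc(F)cc2)cc1)C1CCCCCC1` gives 33 nM. Compound 4 `Cc1cc(S(C)(=O)=O)c(NC(=O)N(Cc2ccc(Oc3ccc(F)cc3)cc2)C2CCCCCC2)c(Cl)n1` carries methylsulfonyl in place of chloro on an aromatic carbon. For the measured compounds named here, no measured step exchanges a chloro for a methylsulfonyl. Going by the values given here, the step from compound 1 to compound 2, a 1.1-fold lower number from compound 1 to compound 2 (0.06 log units; within the scatter), is the only one that swaps a substituent on an aromatic carbon of the core, and it was within the scatter, while a 2.4-fold lower number from compound 1 to compound 3 (0.37 log units; beyond the scatter) and a 2.1-fold lower number from compound 2 to compound 3 (0.32 log units; beyond the scatter) were modest. Compound 4 is therefore expected to stay near compound 3, with a step of a 2.9-fold higher number from compound 3 to compound 4 (0.46 log units; beyond the scatter) in this assay, more likely upward than downward. The estimate for compound 4 is 40 nM, between 12 nM and 130 nM.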

Compound 4, half-maximal inhibitory concentration: 30 nM
For compound 4 the middle estimate is 1.3-fold (0.12 log units) above the measured one; the measured number falls inside the stated range.
By their numbers in this assay, from the lowest: compound 3; then compounds 2, 4 and 1 (each within the scatter of the next).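

In this assay, for the compounds shown here, exchanging the chloro opposite the ring nitrogen for methylsulfonyl gives a 2.1-fold higher number from compound 3 to compound 4 (0.33 log units; beyond the scatter), the first single-substituent exchange on an aromatic carbon of the core to go beyond the scatter. The change also brings the compound level with the two dialkoxy-type and methylsulfanyl-bearing comparators, with a 1.0-fold higher number from compound 2 to compound 4 (0.01 log units; within the scatter) and a 1.1-fold lower number from compound 1 to compound 4 (0.04 log units; within the scatter). Nothing measured here accounts for these steps. On these data alone, whether an amine or a carboxylic acid at this position would stay near compound 3 remains open.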